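A few compounds are considered here, and "the series" means these few. Any claim that something is new, unique, unknown or untested is made for them only; others in the source may bear on it.

Notes on the series. Compound 1 `CCCOc1c(-c2cc(OC)c(OC)c(OC)c2)oc2ccccc2c1=O`, compound 2 `CCCCOc1c(-c2cc(OC)c(OC)c(OC)c2)oc2ccccc2c1=O` and compound 3 `CCC(C)Oc1c(-c2cc(OC)c(OC)c(OC)c2)oc2ccccc2c1=O` share one core and differ only in the saturated chain sitting on an oxygen on an aromatic ring. In a functional assay on LNCaP cells (Homo sapiens) for antiproliferative activity, read by WST assay, with a stated time of 3 days (on this read-out lower numbers stand for stronger inhibition and higher numbers for weaker inhibition), compound 1 gives 5700 nM; compound 2 gives 8900 nM; compound 3 gives 9300 nM. Compound 2 thus stands second highest of the three numbers, with compound 3 nearest and compound 1 furthest, and all three sit within the scatter of one another, so no order among them can be read.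

Compound 4 `CCCC(C)Oc1c(-c2cc(OC)c(OC)c(OC)c2)oc2ccccc2c1=O` has not yet been measured. It differs from compound 2 by methyl in place of hydrogen on a saturated chain carbon bound to an oxygen on an aromatic ring and a saturated chain carbon. The closest measured parallel is the same change made on the shorter chain, which gave a 1.6-fold higher number from compound 1 to compound 3 (0.21 log units; within the scatter). The other way of lengthening the chain, a 1.6-fold higher number from compound 1 to compound 2 (0.19 log units; within the scatter), and the exchange a 1.0-fold higher number from compound 2 to compound 3 (0.02 log units; within the scatter) also stayed within the scatter. On this basis no step beyond the scatter is expected in this assay; if anything, a slightly higher number. Compound 4 is therefore estimated at 12000 nM, with a range from 6000 nM to 25000 nM. The expected step is a 1.3-fold higher number from compound 2 to compound 4 (0.13 log units; within the scatter).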

Compound 4, half-maximal inhibitory concentration: 15100 nM
Compound 4: the middle estimate sits 1.3-fold (0.10 log units) below what was measured; the range from low to high includes it.
By their numbers in this assay, from the lowest: compounds 1, 2, 3 and 4 (each within the scatter of the next, the first and the last beyond it).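

In this assay, the methyl on a saturated chain carbon bound to an oxygen on an aromatic ring now has a second reading on the longer chain, a 1.7-fold higher number from compound 2 to compound 4 (0.23 log units; within the scatter), and it matches the earlier reading on the shorter chain: the same change on two cores in this assay, a 1.6-fold higher number (0.21 log units; within the scatter) from compound 1 to compound 3 and a 1.7-fold higher number (0.23 log units; within the scatter) from compound 2 to compound 4, 1.0-fold (0.02 log units) apart, within the scatter of two such steps. The methyl three bonds along the chain from that oxygen also has a second reading, a 1.6-fold higher number from compound 3 to compound 4 (0.21 log units; within the scatter), and the two readings again agree: the same change on two cores in this assay, a 1.6-fold higher number (0.19 log units; within the scatter) from compound 1 to compound 2 and a 1.6-fold higher number (0.21 log units; within the scatter) from compound 3 to compound 4, 1.0-fold (0.02 log units) apart, within the scatter of two such steps. Within the data shown here, each single methyl stays within the scatter, but with both in place, 1-methylbutyl in place of propyl gives a 2.6-fold higher number from compound 1 to compound 4 (0.42 log units; beyond the scatter), a modest step and the only one beyond the scatter, so compound 1 and compound 4 are the only pair whose order can be read.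

The compounds shown leave open whether a shorter chain such as ethyl would give a lower number than compound 1, and whether a longer chain such as hexyl would carry the numbers further up. They also leave open how a chain carrying an amine or a carboxylic acid on this oxygen would read in this assay.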